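Replacing acetamido with fluoro on compound 2

The compounds below may be only part of what the source reports. "The series", "measured", "known", "first", "only" and "open" are said of these compounds alone.

Going by the values given here, in an ADME assay on microsomes (Mus musculus) for metabolic stability, read by LC-MS, using NADPH, with a stated time of 1 h, tested at 1 uM (a lower number here means slower removal, a higher number faster removal of the compound), compound 2 `CC(=O)Nc1cccc(Cn2cc(-c3ccc4cn[nH]c4c3)ccc2=O)c1` gives 47 mL.min-1.g-1 as the only true number among the three measured compounds. Compound 1 `Nc1n[nH]c2cc(-c3ccc(=O)n(Cc4ccccc4F)c3)ccc12` gives < 10 mL.min-1.g-1 as a limit of the assay and not a number. Compound 3 `Nc1n[nH]c2cc(-c3ccc(=O)n(Cc4cccc(Cl)c4)c3)ccc12` gives < 10 mL.min-1.g-1 as a limit too. Both stand at the limit of < 10 mL.min-1.g-1 in this assay, at which 2 of the 3 values shown sit, and so offer no number to compare.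

Compound 4 `O=c1ccc(-c2ccc3cn[nH]c3c2)cn1Cc1cccc(F)c1` has not yet been measured. It differs from compound 2 by fluoro in place of acetamido on an aromatic carbon and by nothing else. Among the compounds with values here, the only measured step is a step that the two limits leave unreadable from compound 1 to compound 3 and it swaps other groups, so it gives no guide to the size of this change. No step beyond the scatter is therefore expected in this assay for this change, and compound 2 at 47 mL.min-1.g-1 stays the anchor for that expectation. The expected step is a 1.3-fold lower number from compound 2 to compound 4 (0.13 log units; within the scatter) and carries wide uncertainty. For compound 4 the estimate is 35 mL.min-1.g-1 with an expected range from 12 mL.min-1.g-1 to 90 mL.min-1.g-1 as the likely span.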

Compound 4, intrinsic clearance in microsomes: 160 mL.min-1.g-1
Estimate against measurement, compound 4: 4.6-fold (0.66 log units) below, outside the stated range (above it).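

In this assay, going by these compounds alone, this is the first step that can be read, since compound 1 and compound 3 both carry limits of the assay and the step between them cannot be read. Fluoro in place of acetamido on this aromatic carbon, meta to a large group, gives a 3.4-fold higher number from compound 2 to compound 4 (0.53 log units; beyond the scatter), so what sits at this position matters for how fast the compound is removed. Nothing measured here accounts for this rise, which rests on a single pair of compounds.

Still open, on these data alone, is where an amine, a carboxylic acid or a methoxy group on this same carbon would fall relative to compound 2 and compound 4. Also open, as far as these compounds go, is whether the same swap would give a step of similar size on the core of compound 1.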